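The compounds below may be only part of what the source reports. "The series", "measured", "known", "first", "only" and "open" are said of these compounds alone.

In a functional assay on HCT-116 cells (Homo sapiens) for inhibition, read by MTT assay, with a stated time of 72 h (a higher number here means a weaker inhibitor, a lower number a stronger inhibitor), compound 3 `CCOC(=O)Nc1ccc(S(=O)(=O)n2c(C3(O)C=CC(=O)C=C3)cc3ccccc32)cc1` gives 30 nM. This places it level with compound 1 `O=C1C=CC(O)(c2cc3ccccc3n2S(=O)(=O)c2ccccc2)C=C1`, which gives 30 nM, and with compound 2 `Cc1ccc(S(=O)(=O)n2c(C3(O)C=CC(=O)C=C3)cc3ccccc32)cc1`, which gives 30 nM. The next compound, compound 4 `COC(=O)CCc1ccc(S(=O)(=O)n2c(C3(O)C=CC(=O)C=C3)cc3ccccc32)cc1`, keeps the core of compound 3 and differs in one group: 2-(methoxycarbonyl)ethyl in place of (ethoxycarbonyl)amino on an aromatic carbon. Here 2-(methoxycarbonyl)ethyl stands in place of (ethoxycarbonyl)amino on an aromatic carbon, para to a large group.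

Within the data shown here, three measured steps bear on this change. Methyl in place of hydrogen brought no change at the digits printed from compound 1 to compound 2 (within the scatter). (Ethoxycarbonyl)amino in place of hydrogen brought no change at the digits printed from compound 1 to compound 3 (within the scatter), and (ethoxycarbonyl)amino in place of methyl brought no change at the digits printed from compound 2 to compound 3 (within the scatter). None of the three steps leaves the scatter, so the group being removed from compound 3 has shown no measurable effect on the read-out in this assay. Among the measured compounds shown here, no measured compound yet carries 2-(methoxycarbonyl)ethyl, so the entering group itself remains untested, and the estimate rests only on these three neighbours. No step beyond the scatter is expected, in either direction. The expected change is no change at the digits printed from compound 3 to compound 4 (within the scatter). The estimated value for compound 4 is 30 nM, with an expected range from 15 nM to 70 nM.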

Compound 4, half-maximal inhibitory concentration: 30 nM
Estimate against measurement, compound 4: no gap at the digits printed; the range from low to high includes it.
By their numbers in this assay, from the lowest: compounds 1, 2, 3 and 4 (each within the scatter of the next).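

At this position, on an aromatic carbon para to a large group, 2-(methoxycarbonyl)ethyl, with no nitrogen and 0 hydrogen-bond donors, brought no change at the digits printed from compound 3 to compound 4 (within the scatter) in this assay, so the nitrogen and the 1 hydrogen-bond donor of (ethoxycarbonyl)amino are not required for the read-out to stay level. The same holds against the simpler groups: (methoxycarbonyl)methyl in place of hydrogen on the saturated chain carbon brought no change at the digits printed from compound 2 to compound 4 (within the scatter), and 2-(methoxycarbonyl)ethyl in place of hydrogen on the aromatic carbon brought no change at the digits printed from compound 1 to compound 4 (within the scatter), which leaves hydrogen, methyl and both groups of 6 heavy atoms all within the scatter of one another. No independent measurement is available that would explain why the read-out stays level across these groups.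

The compounds shown include no group at this position that moves the read-out beyond the scatter, so it remains open whether a carboxylic acid in place of the methyl ester, an amine or a longer chain would also leave it level. With a single cellular assay shown, it is also open whether this level pattern would hold in any other cell line.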